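Taking the hydroxy off compound 2

The source may hold more compounds than are shown below. What is called first, only, known or untested is meant among the compounds shown, and "the series" means these compounds.

In an ADME assay on PA-1 cells (Homo sapiens) for cytotoxicity, read by MTT assay, with a stated time of 72 h (a lower number here means a stronger inhibitor, a higher number a weaker inhibitor), compound 2 (`COc1ccc(C2=C(c3cc(OC)c(OC)c(OC)c3)C(=O)CC2O)cc1O`) gives < 1 ug/mL as a limit and not a number. Compound 1 (`C=CCOc1cc(C2=C(c3cc(OC)c(OC)c(OC)c3)C(=O)C(O)C2)ccc1OC`) gives > 100 ug/mL as a limit. Compound 3 (`COc1ccc(C2=C(c3cc(OC)c(OC)c(OC)c3)C(=O)C(O)C2)cc1F`) gives > 100 ug/mL as a limit as well. The core of these last two differs from that of compound 2 in where its hydroxy sits.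

Compound 4 (`COc1ccc(C2=C(c3cc(OC)c(OC)c(OC)c3)C(=O)CC2O)cc1`) keeps the core of compound 2. Its difference from compound 2 is hydrogen in place of hydroxy on an aromatic carbon with 3-hydroxy-4-methoxyphenyl becoming 4-methoxyphenyl. For the measured compounds named here, the only measured step is a step that the two limits leave unreadable from compound 1 to compound 3 and it offers no size to carry over. Going by the values given here, it also belongs to the other core, so no measured step gauges this change directly.

Among the compounds with values here, compound 2 remains the only guide, with its limit of < 1 ug/mL as the starting point for the expectation. A modest weakening is expected, and the estimated change is a number no lower from compound 2 to compound 4 (the limit leaves the size open) in that direction. For compound 4 the estimated value is 1 ug/mL with an expected range of 0.2 ug/mL to 10 ug/mL in this assay here.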

Compound 4, half-maximal inhibitory concentration: 3.38 ug/mL
For compound 4 the middle estimate is 3.4-fold (0.53 log units) below the measured one; the measured number falls inside the stated range.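

In this assay, replacing the hydroxy with hydrogen on the aromatic carbon ortho to a methoxy group, turning 3-hydroxy-4-methoxyphenyl into 4-methoxyphenyl, gives an at least 3.3-fold higher number from compound 2 to compound 4 (0.52 log units; beyond the scatter). For the compounds shown here, this is the first readable step on the core of compound 2, and it shows that this hydroxy counts in this assay, which the earlier compounds could not show: their one step lay on the other core and cannot be read. The true size stays open upward, because compound 2 carries a limit and not a number: the limit of < 1 ug/mL in this assay, at which 1 of the 4 values shown sits.

The compounds shown leave open whether an amine or a carboxylic acid in place of this hydroxy would keep the number of compound 2 or fall back towards that of compound 4. They also leave open how the same change would read on the core of compound 1 and compound 3.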